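This account rests on a few compounds, and the source may have more. Where it says the series, first, only, none or still open, it means among the compounds named here.

Of the compounds shown here, three sharing one core have been measured in an assay on isolated protein for inhibition of Ephrin type-A receptor 2 (Homo sapiens), read by thermal shift assay, tested at 10 uM; on this read-out lower numbers stand for weaker stabilisation of the target and higher numbers for stronger stabilisation of the target against heat. Compound 1 `Cc1ccc(F)cc1NC(=O)Nc1cc(C(C)(C)C)nn1-c1ccccc1` gives 1.6 degrees C in this assay. Compound 2 `Cn1nc(-c2ccccc2)cc1NC(=O)Nc1cc(C(F)(F)F)cc(C(F)(F)F)c1` gives 0.9 degrees C. Compound 3 `Cc1ccc(-n2nc(C(C)(C)C)cc2NC(=O)Nc2cc(F)cc(F)c2)cc1` gives 1.9 degrees C. All three numbers lie within the usual scatter of one another, so none of the three compounds can be set apart from the others on this evidence, and compound 3 sits with its two companions in a single narrow band.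

Compound 4 `CC(C)(C)c1cc(NC(=O)Nc2cc(F)cc(F)c2)n(-c2ccc(Br)cc2)n1` has not yet been measured. It differs from compound 3 in one place: bromo in place of methyl on an aromatic carbon, para to a large group; cut one bond further out, the same difference reads 4-methylphenyl to 4-bromophenyl. Among the compounds with values here, no pair of measured compounds shows this exchange on its own, so there is no measured step to lean on. The three measured values, which belong to three different patterns of substitution yet stay within the scatter of each other, give no sign that one exchange of this kind would move the number far. The expected step is a number 0.10 degrees C lower from compound 3 to compound 4 (within the scatter), which amounts to no change beyond the scatter. Compound 4 is therefore estimated at 1.8 degrees C, with a range from 0.7 degrees C to 2.9 degrees C.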

Compound 4, shift of the target's melting temperature: 1.3 degrees C
Compound 4: the middle estimate sits 0.50 degrees C above what was measured; measured number inside the range.
By their numbers in this assay, from the lowest: compounds 2, 4, 1 and 3 (each within the scatter of the next).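

Within the data shown here, this is the first pair in the set that differs in one place only, so one exchange can finally be read by itself rather than inferred from compounds that differ in several places. In this assay, bromo in place of methyl on an aromatic carbon, para to a large group, gives a number 0.60 degrees C lower from compound 3 to compound 4 (within the scatter) and nothing more, which means the 4-methylphenyl and 4-bromophenyl forms cannot be told apart on this read-out, and this position accepts either group without a change beyond the scatter. Nothing shown here offers an explanation of this result, whether for the small size of the step or for anything else about the two groups.

Methyl and bromo are only two groups, so it remains open whether an amine, a carboxylic acid or a longer chain such as propyl at this same position would move the number beyond the scatter. From the compounds shown here alone, it is also open whether the exchange of methyl for bromo would give a similar step if the rest of the molecule differed from compound 3.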